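A few compounds are considered here, and "the series" means these few. Any claim that something is new, unique, unknown or untested is made for them only; others in the source may bear on it.

Measured so far in an ADME assay on a cell-free system (plasma, Rattus norvegicus) for metabolic stability, read by LC-MS, with a stated time of 1 h, tested at 100 uM; a lower number here means that less of the compound is left, a higher number that more of the compound is left:
- compound 1 `CC1=C(c2nc(-c3ccc(C#N)cc3)cs2)C(c2cc3ccccc3n2C)NC(=O)N1`: 95.6%
- compound 2 `CC1=C(c2nc(-c3ccc(C#N)cc3)cs2)C(c2ccc(F)nc2)NC(=O)N1`: 100%

Compound 2, at 100%, lies within the scatter of compound 1. Compound 3 `CC1=C(c2nc(-c3ccc(C#N)cc3)cs2)C(c2ccc(Cl)nc2)NC(=O)N1` follows from compound 2 by one exchange, (chloro in place of fluoro on an aromatic carbon), which turns 6-fluoropyridin-3-yl into 6-chloropyridin-3-yl. No exchange of this kind has been measured. Among the measured compounds shown here, the only measured step, a number 4.4 percentage points higher from compound 1 to compound 2 (within the scatter), replaced a whole 1-methyl-1H-indol-2-yl group and stayed within the scatter. In this assay, the expected size of a number 3 percentage points lower from compound 2 to compound 3 (within the scatter) is therefore nothing beyond the scatter. The estimate for compound 3 is 97%, with an expected range of 88% to 100%.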

Compound 3, percent of the compound remaining: 91.7%
For compound 3 the middle estimate is 5.3 percentage points above the measured one; the measured number falls inside the stated range.
By their numbers in this assay, from the lowest: compounds 3, 1 and 2 (each within the scatter of the next).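

In this assay the halogen exchange on this aromatic carbon next to the ring nitrogen gives a number 8.3 percentage points lower from compound 2 to compound 3 (within the scatter) and so stays within the scatter, even though it is a change at this position alone. Against the indole group, 6-chloropyridin-3-yl gives a number 3.9 percentage points lower from compound 1 to compound 3 (within the scatter) and, like 6-fluoropyridin-3-yl, shows no separation from 1-methyl-1H-indol-2-yl. Nothing available explains either step.

From the compounds shown here alone, whether a methoxy group, an amine or a carboxylic acid on this carbon would move the read-out beyond the scatter remains open. Also open, going by these compounds, is whether the nitrile on the shared core matters here.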